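This account rests on a few compounds, and the source may have more. Where it says the series, first, only, none or still open, it means among the compounds named here.

Measured so far:
- Compound 1, `C#CCSc1nc(N2CCN(C)CC2)c2ccncc2n1`: in a functional assay on MGC-803 cells (Homo sapiens) for inhibition, read by MTT assay, with a stated time of 72 h (on this read-out lower numbers stand for stronger inhibition and higher numbers for weaker inhibition), compound 1 reaches only the assay limit, > 80000 nM.
- Compound 2, `C#CCSc1nc(N2CCN(CC)CC2)c2ccncc2n1`: in this assay compound 2 gives 70600 nM.

Among the measured compounds shown here, compound 2 holds the only numerical value here; the other entry, for compound 1, is a limit rather than a number (the limit of > 80000 nM in this assay, at which 1 of the 2 values shown sits). For the measured compounds named here, the single measured step, an at least 1.1-fold lower number from compound 1 to compound 2 (0.05 log units; that floor lies within the scatter), sits inside the usual scatter.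

Compound 3, `C#CCSc1nc(N2CCN(C(=O)OC(C)(C)C)CC2)c2ccncc2n1`, differs from compound 2 by tert-butoxycarbonyl in place of ethyl on an amine nitrogen in a ring. Going by the values given here, no measured step involves a tert-butoxycarbonyl group at this ring nitrogen; the only step in hand, methyl in place of hydrogen on a saturated chain carbon bound to an amine nitrogen in a ring, barely moved the number. No direction beyond the scatter is therefore supported for compound 3. Compound 3 is expected to land near the value of compound 2, and the estimated step of a 1.0-fold lower number from compound 2 to compound 3 (0.00 log units; within the scatter) carries wide uncertainty. The estimate for compound 3 in this assay is 70000 nM, in a range from 20000 nM to 250000 nM, with a real chance that only a limit is reported.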

Compound 3, half-maximal inhibitory concentration: > 80000 nM
Compound 3 gave a limit, no number (the forecaster's own chance of this, stated with the estimate: 45%); middle value at least 1.1-fold (0.05 log units) from the limit.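

Compound 3 puts tert-butoxycarbonyl on the ring nitrogen, a group with more heavy atoms than ethyl and with a carbonyl, and this assay records an at least 1.1-fold higher number from compound 2 to compound 3 (0.05 log units; that floor lies within the scatter). This change therefore gives no sign of stronger inhibition, although the true size of the step remains hidden. The step between compound 1 and compound 3 cannot be read because both ends are limits, and the series now sits mostly at that ceiling: the limit of > 80000 nM in this assay, at which 2 of the 3 values shown sit.

As far as these compounds go, it remains open whether a quite different group on this ring nitrogen, such as a benzyl group, an acetyl group or a single hydrogen, would bring the number well down. These compounds also cannot show whether a real difference among such groups would appear once values fall clear of the limit.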